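The source may hold more compounds than are shown below. What is called first, only, known or untested is meant among the compounds shown, and "the series" means these compounds.

Measured compounds:
compound 1, `CCOC(=O)C(C)C(O)(c1ccc(OC)c(OC)c1OC)c1cccc2ccccc12`: 4000 nM
compound 2, `COc1cc(COC(c2ccc(OC)c(OC)c2OC)c2cccc3ccccc23)cc(OC)c1`: 17500 nM

Both were run in a functional assay on A549 cells (Homo sapiens) for inhibition, read by sulforhodamine B assay, with a stated time of 48 h; a lower number here means a stronger inhibitor, a higher number a weaker inhibitor. Compound 1 gives 4000 nM and holds the lowest of the two numbers. Compound 2 gives 17500 nM, a good way higher and beyond the usual scatter. Going by the values given here, the two differ in more than one place, so no single step connects them; only the two values themselves are known.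

Compound 3, `COc1ccc(C(O)(C/C=C\c2ccccc2)c2cccc3ccccc23)c(OC)c1OC`, awaits measurement in this assay. Against compound 1 the change is one: 3-phenylprop-2-en-1-yl in place of 1-(ethoxycarbonyl)ethyl on a saturated chain carbon bound to two aromatic carbons and an oxygen on a saturated carbon. Among the compounds with values here, no measured pair shows a change of this kind, so there is nothing to gauge it by. The expected step is a 1.4-fold higher number from compound 1 to compound 3 (0.14 log units; within the scatter), estimated as small and, if anything, toward a weaker inhibitor, not certainly beyond the scatter. For compound 3 the estimate in this assay is 5500 nM, expected to fall between 1500 nM and 20000 nM.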

Compound 3, half-maximal inhibitory concentration: 17600 nM
Beside the measured number, compound 3's estimate is 3.2-fold (0.51 log units) below it; the range from low to high includes it.
By their numbers in this assay, from the lowest: compound 1; then compounds 2 and 3 (each within the scatter of the next).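

In this assay, going by these compounds alone, the position on a saturated chain carbon bound to two aromatic carbons and an oxygen on a saturated carbon proves sensitive to its substituent: 3-phenylprop-2-en-1-yl in place of 1-(ethoxycarbonyl)ethyl gives a 4.4-fold higher number from compound 1 to compound 3 (0.64 log units; beyond the scatter) and is the only single change read here. The entering group adds a six-membered aromatic ring and has no hydrogen-bond acceptors, while the leaving group has two, so this one step cannot separate these differences. No measurement at hand bears on the cause of the step.

From the compounds shown here alone, it remains open whether the ester of compound 1 matters as such, or whether a carboxylic acid, an amine or a longer saturated carbon chain at this place would give a lower or higher number. A single pair also sets no trend for other substituents on this carbon.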